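Series notes: alkoxy to arylamino exchange on the shared core

This account rests on a few compounds, and the source may have more. Where it says the series, first, only, none or still open, it means among the compounds named here.

Three compounds of the series carry a variable group on a double-bonded ring carbon of the shared core: compound 1 `CC(C)OC1=C(C(=O)c2ccccc2)C(c2ccc(Br)cc2)N(CCCn2ccnc2)C1=O`, compound 2 `CCCCOC1=C(C(=O)c2ccccc2)C(c2ccc(Br)cc2)N(CCCn2ccnc2)C1=O` and compound 3 `O=C(C1=C(OC2CCCCC2)C(=O)N(CCCn2ccnc2)C1c1ccc(Br)cc1)c1ccccc1`. In a functional assay on A549 cells (Homo sapiens) for antiproliferative activity, read by MTT assay, with a stated time of 72 h (on this read-out higher numbers stand for weaker inhibition and lower numbers for stronger inhibition), compound 1 gives 8720 nM, compound 2 gives 18500 nM and compound 3 gives 31200 nM, so compound 3 stands highest of the three, though its gap to compound 2 is within the scatter while its gap to compound 1 is beyond it. The measured steps are all alkoxy exchanges: a 2.1-fold higher number from compound 1 to compound 2 (0.33 log units; beyond the scatter), a 3.6-fold higher number from compound 1 to compound 3 (0.55 log units; beyond the scatter) and a 1.7-fold higher number from compound 2 to compound 3 (0.23 log units; within the scatter), all modest.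

Compound 4 `Cc1ccc(NC2=C(C(=O)c3ccccc3)C(c3ccc(Br)cc3)N(CCCn3ccnc3)C2=O)cc1` differs from compound 3 by (4-methylphenyl)amino in place of cyclohexyloxy on a double-bonded ring carbon. Among the measured compounds shown here, none of the measured steps concerns an oxygen-to-nitrogen exchange or an aromatic ring at this place, so they do not bear directly on it; they show only that this position tolerates changes with modest shifts in this assay. Given that the whole measured range spans compound 1 through compound 3, the number for compound 4 is estimated with wide uncertainty at 12000 nM, range 2500 nM to 50000 nM, which means an expected step of a 2.6-fold lower number from compound 3 to compound 4 (0.41 log units; beyond the scatter).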

Compound 4, half-maximal inhibitory concentration: 29400 nM
The estimate for compound 4 lay 2.5-fold (0.39 log units) below the measured number; low and high end bracket the measured number.
By their numbers in this assay, from the lowest: compound 1; then compounds 2, 4 and 3 (each within the scatter of the next).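

In this assay, (4-methylphenyl)amino in place of cyclohexyloxy on the double-bonded ring carbon gives a 1.1-fold lower number from compound 3 to compound 4 (0.03 log units; within the scatter), so this position accepts an aromatic ring on a nitrogen link, with a hydrogen-bond donor that the alkoxy groups lack, and the number stays within the scatter of compound 3. The same exchange set against butoxy gives a 1.6-fold higher number from compound 2 to compound 4 (0.20 log units; within the scatter), also within the scatter, while set against isopropoxy it gives a 3.4-fold higher number from compound 1 to compound 4 (0.53 log units; beyond the scatter), the only one of the three steps beyond the scatter, so compound 1 remains apart from compounds 2, 3 and 4 and the arylamino group brings no step beyond the scatter towards a lower number than any alkoxy group shown. Nothing available explains these numbers. The change at this position swaps the linking atom and the ring type together, so the compounds shown leave their separate contributions open: a cyclohexylamino group would isolate the nitrogen link, and a phenoxy group the aromatic ring. Also open, from the compounds shown here alone, is whether an isopropylamino group would keep the number of compound 1 or join the others.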